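The compounds below may be only part of what the source reports. "The series", "measured", "known", "first", "only" and "open" are said of these compounds alone.

Measured in a functional assay on A549 cells (Homo sapiens) for antiproliferative activity, read by MTT assay, with a stated time of 48 h; on this read-out lower numbers stand for stronger inhibition and higher numbers for weaker inhibition:
- compound 1 `CCCC(C)Oc1ccc(C(=O)/C=C/c2c(/C=C/c3ccc(OC)cc3)cc(OC)cc2OC)cc1`: 9.4 ug/mL
- compound 2 `COc1ccc(/C=C/c2cc(OC)cc(OC)c2/C=C/C(=O)c2cccc(Cl)c2)cc1`: 5.6 ug/mL

Among the measured compounds shown here, with only two numbers so far, compound 2 at 5.6 ug/mL cannot be ranked with any confidence. Its value and that of compound 1 at 9.4 ug/mL lie within the usual scatter of each other.

The next compound is compound 3 `COc1ccc(/C=C/c2cc(OC)cc(OC)c2/C=C/C(=O)c2ccc(F)cc2)cc1`, which shares its core with compound 2. The change is 4-fluorophenyl in place of 3-chlorophenyl on a carbonyl carbon.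

For the measured compounds named here, only one measured step bears on this swap, since it also exchanges the group on the carbonyl carbon: a 1.7-fold lower number from compound 1 to compound 2 (0.22 log units; within the scatter). That step replaced a much larger group and still stayed within the scatter. Going by the values given here, it is only a single step, however, and no measured compound carries the 4-fluorophenyl group.

No step beyond the scatter is therefore expected in this assay, and no direction can be favoured. The expected step is a 1.2-fold higher number from compound 2 to compound 3 (0.06 log units; within the scatter). For compound 3 the estimate is 6.5 ug/mL, with an expected range from 3 ug/mL to 14 ug/mL.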

Compound 3, half-maximal inhibitory concentration: 6.6 ug/mL
Estimate against measurement, compound 3: 1.0-fold (0.01 log units) below, within the range that was stated.
By their numbers in this assay, from the lowest: compounds 2, 3 and 1 (each within the scatter of the next).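

In this assay, the swap on the carbonyl carbon gives a 1.2-fold higher number from compound 2 to compound 3 (0.07 log units; within the scatter); since 3-chlorophenyl and 4-fluorophenyl differ both in the halogen and in the number in the group's name, this single step cannot separate those two changes, and together they leave the number within the scatter. The other new step, a 1.4-fold lower number from compound 1 to compound 3 (0.15 log units; within the scatter), puts fluoro in place of 1-methylbutoxy on an aromatic carbon, so a single halogen atom and a branched chain joined through oxygen also give numbers that cannot be told apart, which extends the picture from one swap of the whole group to a change of the substituent alone. The data shown include no measurement that could explain why these three compounds lie so close together.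

The compounds shown leave open whether a group of another kind on that aromatic ring, such as an amine or a carboxylic acid, would move the number beyond the scatter. They also leave open the separate roles of the halogen and its place, which a one-place partner such as 4-chlorophenyl on the same carbonyl carbon could begin to show.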